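This account rests on a few compounds, and the source may have more. Where it says the series, first, only, none or still open, it means among the compounds named here.

Compound 1 `CCC[C@@]1(O)[C@@H](CO)O[C@@H](n2ccc(=O)[nH]c2=O)[C@@H]1O` gives only a limit in a functional assay on KB cells (Homo sapiens), read by MTT assay (a lower number here means a stronger inhibitor, a higher number a weaker inhibitor), namely > 350000 nM.
Compound 2 `C=C[C@@]1(O)[C@@H](CO)O[C@@H](n2ccc(=O)[nH]c2=O)[C@@H]1O` gives 51800 nM in this assay.
Compound 3 `CC#C[C@@]1(O)[C@@H](CO)O[C@@H](n2ccc(=O)[nH]c2=O)[C@@H]1O` has not yet been measured.

Compound 2 holds the only true number shown; the other value is a limit. For the measured compounds named here, the single measured step is an at least 6.7-fold lower number from compound 1 to compound 2 (0.82 log units; beyond the scatter), and the limit of > 350000 nM in this assay, at which 1 of the 2 values shown sits, means its real size is not known. Compound 3 differs from compound 2 by prop-1-yn-1-yl in place of vinyl on a saturated ring carbon. Going by the values given here, as the one measured step went toward the unsaturated group, compound 3 is expected to sit near compound 2 or somewhat lower in this assay, an estimated 30000 nM, a step of a 1.7-fold lower number from compound 2 to compound 3 (0.24 log units; within the scatter), within a range from 5000 nM to 200000 nM.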

Compound 3, half-maximal inhibitory concentration: 70800 nM
The estimate for compound 3 lay 2.4-fold (0.37 log units) below the measured number, and the stated range covers the measured number.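

In this assay the result of a 1.4-fold higher number from compound 2 to compound 3 (0.14 log units; within the scatter) means that prop-1-yn-1-yl and vinyl cannot be told apart on this saturated ring carbon. The result of an at least 4.9-fold lower number from compound 1 to compound 3 (0.69 log units; beyond the scatter) shows that prop-1-yn-1-yl, like vinyl, stands apart from propyl here. From the compounds shown here alone, the true size of that gap stays unknown because compound 1 carries only a limit: the limit of > 350000 nM in this assay, at which 1 of the 3 values shown sits.

Still open, going by these compounds, is how a longer alkynyl chain or an amine on this carbon would read in this assay. Whether the separation from propyl extends beyond these two unsaturated groups also remains unsettled.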